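This account rests on a few compounds, and the source may have more. Where it says the series, first, only, none or still open, it means among the compounds named here.

The shared core of these compounds, seen in compound 1 `CCN1CCCC(n2cc(S(=O)(=O)c3ccccc3)c3ccccc32)C1`, carries a phenyl group and a cyclic amine on the aromatic nitrogen. In a functional assay on HeLa cells for agonist activity at 5-hydroxytryptamine receptor 6 (Homo sapiens), read by cAMP accumulation and immunoassay, with a stated time of 10 min (a lower number here means that less compound is needed, a higher number that more compound is needed for the effect), compound 1 gives 31 nM. Compound 2 `O=S(=O)(c1ccccc1)c1cn(C2CCN(Cc3ccccc3)C2)c2ccccc12` stands as "not determined" (no result reported) in this assay, so no number is on hand for it. Compound 3 `O=S(=O)(c1ccccc1)c1cn(C2CCNC2)c2ccccc12` gives 60 nM in this assay; of the two numbers shown it is the upper one, yet the step of a 1.9-fold higher number from compound 1 to compound 3 (0.29 log units; within the scatter) is within the scatter, so compound 1 and compound 3 cannot be told apart on this assay. Compound 4 `O=S(=O)(c1cccc(Cl)c1)c1cn(C2CCNC2)c2ccccc12` differs from compound 3 by chloro in place of hydrogen on an aromatic carbon. Among the compounds with values here, no measured step bears on this change: the only step on hand, a 1.9-fold higher number from compound 1 to compound 3 (0.29 log units; within the scatter), swaps pyrrolidin-3-yl for 1-ethylpiperidin-3-yl and says nothing about a substituent on the phenyl. Lacking a comparable step, the expectation for compound 4 is a step of no more than the scatter, so the estimated step of a 1.2-fold lower number from compound 3 to compound 4 (0.08 log units; within the scatter) is small. Compound 4 is therefore expected to give 50 nM in this assay, within a range from 15 nM to 170 nM.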

Compound 4, half-maximal effective concentration: 125 nM
Beside the measured number, compound 4's estimate is 2.5-fold (0.40 log units) below it, within the range that was stated.
By their numbers in this assay, from the lowest: compounds 1 and 3 (each within the scatter of the next); then compound 4.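

In this assay, within the data shown here, the change from phenyl to 3-chlorophenyl gives the first reading on a substituent of this ring: a 2.1-fold higher number from compound 3 to compound 4 (0.32 log units; beyond the scatter) is a modest step, only just past the usual scatter. The one earlier step, a 1.9-fold higher number from compound 1 to compound 3 (0.29 log units; within the scatter), concerned the cyclic amine on the aromatic nitrogen and stayed within the scatter, so a chloro on this carbon is the first change shown to move the number, and it moves it upward, towards more compound being needed. Nothing on hand accounts for this step.

The compounds shown leave open whether a fluoro, a methoxy or an amine in the same place would shift the number as chloro does. They also leave open whether chloro would give a similar step with 1-ethylpiperidin-3-yl on the aromatic nitrogen.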